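From a Dimethylamino Ring to a Nitro Ring

The source may report more compounds than this note shows. Statements on the series, on what has been measured and on what is new or still open speak of the compounds shown alone.

Measured in a functional assay on MCF7 cells (Homo sapiens) for cytotoxicity, read by MTT assay, with a stated time of 24 h; on this read-out lower numbers stand for stronger inhibition and higher numbers for weaker inhibition:
- compound 1 `C/C(=N\NC(=O)/C(C#N)=C/c1ccccc1)c1c(O)c2ccc(O)cc2oc1=O`: 19200 nM
- compound 2 `COc1cc(/C=C(\C#N)C(=O)N/N=C(\C)c2c(O)c3ccc(O)cc3oc2=O)ccc1O`: 13700 nM
- compound 3 `C/C(=N\NC(=O)/C(C#N)=C/c1ccc(N(C)C)cc1)c1c(O)c2ccc(O)cc2oc1=O`: 3420 nM

Compound 3 has the lowest number of the three, and it stands apart from both others by more than the scatter. Compound 4 `C/C(=N\NC(=O)/C(C#N)=C/c1ccccc1[N+](=O)[O-])c1c(O)c2ccc(O)cc2oc1=O` carries 2-nitrophenyl in place of 4-(dimethylamino)phenyl on a double-bonded chain carbon bound to a double-bonded chain carbon. Among the compounds with values here, two measured steps bear on this change, a 5.6-fold lower number from compound 1 to compound 3 (0.75 log units; beyond the scatter) and a 4.0-fold lower number from compound 2 to compound 3 (0.60 log units; beyond the scatter). Both end at the dimethylamino compound. The third step, a 1.4-fold lower number from compound 1 to compound 2 (0.15 log units; within the scatter), involves no dimethylamino group. Within the data shown here, no measured compound carries a nitro group, so the uncertainty is wide. A move to a higher number in this assay is expected, of similar size to those two steps. The expected step is a 3.2-fold higher number from compound 3 to compound 4 (0.51 log units; beyond the scatter). Compound 4 is estimated at 11000 nM, with an expected range from 4000 nM to 30000 nM.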

Compound 4, half-maximal inhibitory concentration: 9180 nM
Compound 4: the middle estimate sits 1.2-fold (0.08 log units) above what was measured; low and high end bracket the measured number.
By their numbers in this assay, from the lowest: compound 3; then compounds 4, 2 and 1 (each within the scatter of the next, the first and the last beyond it).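

In this assay, 2-nitrophenyl on this double-bonded chain carbon does not match 4-(dimethylamino)phenyl (a 2.7-fold higher number from compound 3 to compound 4 (0.43 log units; beyond the scatter)), yet nitro in place of hydrogen still gives a real move from the plain phenyl compound (a 2.1-fold lower number from compound 1 to compound 4 (0.32 log units; beyond the scatter)). So a lower number than phenyl is not unique to the dimethylamino group, while 2-nitrophenyl and 4-hydroxy-3-methoxyphenyl cannot be told apart (a 1.5-fold lower number from compound 2 to compound 4 (0.17 log units; within the scatter)). Nothing measured here explains these differences. Still open, going by these compounds, is whether a plain amino group or a carboxylic acid on this phenyl ring would fall nearer compound 3 or compound 4.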